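A few compounds are considered here, and "the series" means these few. Any claim that something is new, unique, unknown or untested is made for them only; others in the source may bear on it.

Measured so far in a functional assay on PC-12 cells (Rattus norvegicus) for cytotoxicity, read by MTT assay, with stated times of 2 h and 24 h, tested at 5 uM; on this read-out lower numbers stand for a weaker effect and higher numbers for a stronger effect at the one concentration tested:
compound 1 `CC(C)(C)c1ccc(-n2nc(-c3ccc(C(F)(F)F)cc3O)nc2-c2ccccc2O)cc1`: 77.8%
compound 2 `Oc1cc(C(F)(F)F)ccc1-c1nc(-c2ccccc2O)n(-c2ccc(OC(F)(F)F)cc2)n1`: 84.9%
compound 3 `Oc1cc(C(F)(F)F)ccc1-c1nc(-c2ccccc2O)n(-c2ccccc2Cl)n1`: 90.6%

Compound 3 stands at the top of these three numbers, with compound 2 within the scatter of it, while the step of a number 12.8 percentage points higher from compound 1 to compound 3 (beyond the scatter) lies beyond the scatter. Compound 4 `Oc1cc(C(F)(F)F)ccc1-c1nc(-c2ccccc2O)n(-c2cccc(C(F)(F)F)c2)n1` differs from compound 3 by one change: 3-(trifluoromethyl)phenyl in place of 2-chlorophenyl on an aromatic nitrogen. Every measured step alters the same aryl group on that aromatic nitrogen, and none was large: a number 7.1 percentage points higher from compound 1 to compound 2 (within the scatter) and a number 5.7 percentage points higher from compound 2 to compound 3 (within the scatter) stayed within the scatter, and a number 12.8 percentage points higher from compound 1 to compound 3 (beyond the scatter) was only modest. A swap of this kind is therefore expected to move this assay little, and the expected step is a number 4.6 percentage points lower from compound 3 to compound 4 (within the scatter). Compound 4 is accordingly estimated at 86%, between 72% and 97%.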

Compound 4, a percentage reported as activity, at one concentration (the size of the read-out at that concentration, not a potency): 92.2%
Compound 4: the middle estimate sits 6.2 percentage points below what was measured, and the stated range covers the measured number.
By their numbers in this assay, from the lowest: compounds 1, 2, 3 and 4 (each within the scatter of the next, the first and the last beyond it).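

The 3-(trifluoromethyl)phenyl group on the aromatic nitrogen adds another aryl group to this position, and in this assay the swap gives a number 1.6 percentage points higher from compound 3 to compound 4 (within the scatter) and a number 7.3 percentage points higher from compound 2 to compound 4 (within the scatter), so compound 4 separates from neither neighbour. Only the comparison with the 4-(tert-butyl)phenyl group, a number 14.4 percentage points higher from compound 1 to compound 4 (beyond the scatter), leaves the scatter, and that step is modest. No supporting evidence bears on why these steps are small. Still open, from the compounds shown here alone, is whether an aryl group carrying an amine or a carboxylic acid, or a longer alkyl chain replacing the aryl group on that nitrogen, would shift this assay further.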